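The source may report more compounds than this note shows. Statements on the series, on what has been measured and on what is new or still open speak of the compounds shown alone.

Measured in a functional assay on BV-2 cells (Mus musculus) for inhibition, read by Griess assay, with a stated time of 24 h; on this read-out higher numbers stand for weaker inhibition and lower numbers for stronger inhibition:
- compound 1 `COc1ccc(Br)cc1-c1cc(COCc2ccccc2)on1`: > 200000 nM (a limit)
- compound 2 `C=CCc1ccc(OC)c(-c2cc(COCC(=O)OCC)on2)c1`: 25900 nM

Going by the values given here, compound 2 holds the only actual number so far, 25900 nM. Compound 1 gives only a limit.

The next compound is compound 3 `C=CCc1ccc(OC)c(-c2cc(COCc3ccccc3)on2)c1`. It differs from compound 2 by phenyl in place of ethoxycarbonyl on a saturated chain carbon bound to an oxygen on a saturated carbon, with phenyl in place of ethoxycarbonyl on a saturated chain carbon bound to an oxygen on a saturated carbon. The same change reads as (ethoxycarbonyl)methoxy to benzyloxy.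

Among the compounds with values here, no measured step covers this change. Compound 1 also carries benzyloxy and reaches only a limit, > 200000 nM. On that ground, a moderate shift toward weaker inhibition is expected in this assay. The estimated change is a 1.9-fold higher number from compound 2 to compound 3 (0.29 log units; within the scatter). For compound 3 the expected value is 50000 nM, with an estimated range of 15000 nM to 180000 nM.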

Compound 3, half-maximal inhibitory concentration: > 200000 nM
Compound 3: no number, only a limit; the forecaster's own chance of this, stated with the estimate: 25%; at least 4.0-fold (0.60 log units) between middle value and limit.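

In this assay, going by these compounds alone, the first readable step falls on a saturated chain carbon bound to an oxygen on a saturated carbon: an at least 7.7-fold higher number from compound 2 to compound 3 (0.88 log units; beyond the scatter). Of the two groups seen at this place, only (ethoxycarbonyl)methoxy gives a number; benzyloxy gives only a limit in both compounds that carry it, so the change has now been isolated on an otherwise unchanged structure. The step for allyl in place of bromo on an aromatic carbon cannot be read, and the gap for phenyl in place of ethoxycarbonyl is bounded on one side only, both limits being the same: the limit of > 200000 nM in this assay, at which 2 of the 3 values shown sit.

The compounds shown leave open how a carboxylic acid or an amide in place of ethoxycarbonyl would read at this place. Also open, going by these compounds, is whether bromo in place of allyl would give a number when (ethoxycarbonyl)methoxy is kept.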